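Para Substituent Swap on the Arylsulfonamide: Methoxy to tert-Butyl

The compounds below may be only part of what the source reports. "The series", "measured", "known", "first", "only" and "open" are said of these compounds alone.

The series shares one core, built from a cyclopropyl ketone on a phenyl ether, a propyl chain, a pyrrolidine and an arylsulfonamide. In an assay on isolated protein for binding affinity to histamine H2 receptor (Homo sapiens) (on this read-out lower numbers stand for stronger inhibition and higher numbers for weaker inhibition), compound 1 `O=C(c1ccc(OCCCN2CC[C@H](NS(=O)(=O)c3ccc(Br)cc3)C2)cc1)C1CC1` gives 290 nM. Compound 2 `O=C(c1ccc(OCCCN2CC[C@H](NS(=O)(=O)c3ccc(F)cc3)C2)cc1)C1CC1` gives 500 nM in this assay, and compound 3 `COc1ccc(S(=O)(=O)N[C@H]2CCN(CCCOc3ccc(C(=O)C4CC4)cc3)C2)cc1` gives 1000 nM. Compound 3 therefore holds the highest number of the three: its nearest neighbour is compound 2, within the scatter, and its furthest is compound 1, beyond the scatter. The measured steps show a 1.7-fold higher number from compound 1 to compound 2 (0.24 log units; within the scatter), a 3.4-fold higher number from compound 1 to compound 3 (0.54 log units; beyond the scatter) and a 2.0-fold higher number from compound 2 to compound 3 (0.30 log units; within the scatter).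

Compound 4 `CC(C)(C)c1ccc(S(=O)(=O)N[C@H]2CCN(CCCOc3ccc(C(=O)C4CC4)cc3)C2)cc1` is obtained from compound 3 by the change (tert-butyl in place of methoxy on an aromatic carbon). Going by the values given here, no measured step introduces a tert-butyl group, so the three para-substituent steps are the only guide; they indicate that a change at this aromatic carbon can shift this assay by a modest amount, with the methoxy compound at the high end. An improvement of modest size is expected for compound 4, and the step is estimated as a 2.0-fold lower number from compound 3 to compound 4 (0.30 log units; within the scatter). For compound 4 the expected value in this assay is 500 nM, with a range from 150 nM to 1700 nM.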

Compound 4, inhibition constant: 730 nM
For compound 4 the middle estimate is 1.5-fold (0.16 log units) below the measured one, and the stated range covers the measured number.
By their numbers in this assay, from the lowest: compounds 1, 2, 4 and 3 (each within the scatter of the next, the first and the last beyond it).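

In this assay, exchanging methoxy, which carries a hydrogen-bond acceptor, for tert-butyl, which carries none, gives a 1.4-fold lower number from compound 3 to compound 4 (0.14 log units; within the scatter) and so leaves no difference that can be separated from the scatter. Going by these compounds alone, the comparison with the fluoro compound reads the same, with a 1.5-fold higher number from compound 2 to compound 4 (0.16 log units; within the scatter) as the step, whereas the comparison with the bromo compound, a 2.5-fold higher number from compound 1 to compound 4 (0.40 log units; beyond the scatter), is the only new step to lie beyond the scatter. This aromatic carbon therefore takes a tert-butyl group with a number inside the range already spanned by bromo, fluoro and methoxy, and bromo remains the only one of the four substituents separated from more than one other, from both methoxy and tert-butyl. Nothing available bears on why these substituents give the numbers they do.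

The compounds shown leave open how an amine, a carboxylic acid or a nitrile at this same aromatic carbon would read in this assay, since all four substituents shown lack a charge. They also leave open whether the pattern among these four groups would hold with a longer chain in place of the propyl chain of the shared core.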